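The source may hold more compounds than are shown below. What is called first, only, known or untested is meant among the compounds shown, and "the series" means these compounds.

Compound 3 `O=c1[nH]cnc2c1c(-c1cc3ccccc3o1)cn2[C@@H]1O[C@H](CO)[C@@H](O)[C@H]1O` carries a 1-benzofuran-2-yl group, and in a functional assay on K562 cells (Homo sapiens), read by MTT assay, with a stated time of 72 h (on this read-out lower numbers stand for stronger inhibition and higher numbers for weaker inhibition), compound 3 reaches only a limit of the assay, > 20000 nM. That limit is the limit of > 20000 nM in this assay, at which 1 of the 3 values shown sits. Compound 4 `O=c1[nH]cnc2c1c(-c1cccs1)cn2[C@@H]1O[C@H](CO)[C@@H](O)[C@H]1O` changes one part: thiophen-2-yl in place of 1-benzofuran-2-yl on an aromatic carbon. Among the measured compounds shown here, no measured pair shows this exact exchange. The nearest comparison is on a different core: compound 1 `COc1ncnc2c1c(I)cn2[C@@H]1O[C@H](CO)[C@@H](O)[C@H]1O` gives 14800 nM in this assay, compound 2 `COc1ncnc2c1c(-c1cccs1)cn2[C@@H]1O[C@H](CO)[C@@H](O)[C@H]1O` gives 6200 nM, and the step of a 2.4-fold lower number from compound 1 to compound 2 (0.38 log units; beyond the scatter) shows that thiophen-2-yl can lower the number. Since compound 3 stands at a limit, the size of the step of an at least 1.3-fold lower number from compound 3 to compound 4 (0.12 log units; that floor lies within the scatter) is only expected, not measured. Compound 4 is estimated at 15000 nM, within 5000 nM to 45000 nM, with a real chance that it too ends at a limit.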

Compound 4, half-maximal inhibitory concentration: > 20000 nM
Compound 4 ended at the assay's limit; the forecaster's own chance of this, stated with the estimate: 40%; at least 1.3-fold (0.12 log units) between middle value and limit.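

Among the compounds shown here, compound 3 and compound 4 both stop at the same assay limit, so no step between them can be read: the limit of > 20000 nM in this assay, at which 2 of the 4 values shown sit. The compounds shown leave open whether thiophen-2-yl or 1-benzofuran-2-yl gives the lower number on this shared core.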